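Bromoacetamido analogue in the anilide series

The source may report more compounds than this note shows. Statements on the series, on what has been measured and on what is new or still open speak of the compounds shown alone.

Measured compounds:
compound 1 `COc1cccc(-n2nnc(-c3ccccc3NC(=O)c3ccc(N)cc3)n2)c1` – 211 nM
compound 2 `COc1cccc(-n2nnc(-c3ccccc3NC(=O)c3ccc(NC(C)=O)cc3)n2)c1` – 520 nM

Both compounds share one core and differ only at the nitrogen on the aromatic ring of the anilide. In a functional assay on NCI-H460 cells (Homo sapiens) for positive allosteric modulation, read by MTT assay, with stated times of 2 h and 72 h, tested at 10 uM (on this read-out higher numbers stand for weaker inhibition and lower numbers for stronger inhibition), compound 1 gives 211 nM and compound 2 gives 520 nM. Within the data shown here, the single step measured so far, a 2.5-fold higher number from compound 1 to compound 2 (0.39 log units; beyond the scatter), is beyond the scatter but modest. Compound 2 therefore stands at the higher of the two numbers, with compound 1 the nearer and only neighbour.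

Compound 3 `COc1cccc(-n2nnc(-c3ccccc3NC(=O)c3ccc(NC(=O)CBr)cc3)n2)c1` is the next member. Its difference from compound 2 is bromo in place of hydrogen on a saturated chain carbon bound to a carbonyl carbon. Among the measured compounds shown here, no measured step concerns a change on the acetyl carbon itself; the only step available, a 2.5-fold higher number from compound 1 to compound 2 (0.39 log units; beyond the scatter), concerns the acetyl group as a whole and cannot be carried over directly. The expectation for this assay is thus a step of no clear direction, most likely within the scatter, written as a 1.0-fold lower number from compound 2 to compound 3 (0.02 log units; within the scatter). Compound 3 is estimated at 500 nM, with a range from 200 nM to 1300 nM.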

Compound 3, half-maximal inhibitory concentration: 250 nM
Beside the measured number, compound 3's estimate is 2.0-fold (0.30 log units) above it; measured number inside the range.
By their numbers in this assay, from the lowest: compounds 1 and 3 (each within the scatter of the next); then compound 2.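

In this assay, the change from methyl to bromomethyl gives a 2.1-fold lower number from compound 2 to compound 3 (0.32 log units; beyond the scatter) and so shows that a single heavy atom on the saturated chain carbon bound to a carbonyl carbon can shift the number, which the earlier step on the acetyl group as a whole could not show. Acylation of the nitrogen on the aromatic ring therefore does not by itself go with a higher number: compound 2 fits that reading, but compound 3 goes against it, with a 1.2-fold higher number from compound 1 to compound 3 (0.07 log units; within the scatter) as the step from the free amine, so the free amine and the acetamido to ((bromomethyl)carbonyl)amino change are not told apart here. Nothing available bears on the origin of these steps.

As far as these compounds go, it remains open whether the shift is specific to bromine or would also appear with chlorine, fluorine or a hydroxyl group on the same carbon. A dimethylamino group on that carbon, or a longer chain such as propanoyl or 3-bromopropanoyl on the nitrogen, would show how far this position tolerates further change.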